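Working notes: from butyl to sec-butyl

The source may report more compounds than this note shows. Statements on the series, on what has been measured and on what is new or still open speak of the compounds shown alone.

Measured in a physicochemical assay for lipophilicity; a lower number here means a more polar compound, a higher number a more lipophilic compound:
- compound 1 `C/C=C/C=C/C(=O)OCC`: 1.84
- compound 2 `C/C=C/C=C/C(=O)OCCCC`: 2.71

Compound 2 stands higher of the two on 2.71. The move to compound 3 `C/C=C/C=C/C(=O)OC(C)CC` is sec-butyl in place of butyl on an oxygen next to a carbonyl group. Among the measured compounds shown here, the only measured step, a number 0.87 log units higher from compound 1 to compound 2 (beyond the scatter), added ethyl to the chain, whereas here the atoms stay the same and are joined differently. For the measured compounds named here, that step therefore bears only loosely, and no measured step isolates this change. A small drop in this assay is expected, much smaller than that step and near the scatter, with an estimated a number 0.21 log units lower from compound 2 to compound 3 (within the scatter). The estimate for compound 3 is 2.5, expected between 2.2 and 2.8.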

Compound 3, partition coefficient: 2.72
The estimate for compound 3 lay 0.22 log units below the measured number, and the stated range covers the measured number.
By their numbers in this assay, from the lowest: compound 1; then compounds 2 and 3 (each within the scatter of the next).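

In this assay sec-butyl in place of butyl on an oxygen next to a carbonyl group gives a number 0.01 log units higher from compound 2 to compound 3 (within the scatter) and so this rearrangement of the same atoms is not resolved at this position. Ethyl in place of hydrogen on the saturated chain carbon bound to that oxygen gives a number 0.88 log units higher from compound 1 to compound 3 (beyond the scatter) and this modest step stands alongside a number 0.87 log units higher from compound 1 to compound 2 (beyond the scatter) for the unbranched chain. Nothing available explains why butyl and sec-butyl read alike.

From the compounds shown here alone, whether tert-butyl or a longer chain on that oxygen would also read like butyl remains open. So does the effect on this reading of an amine on the chain.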